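Chloro for Ethoxy in a Series Without Measurable Cytotoxicity

This account rests on a few compounds, and the source may have more. Where it says the series, first, only, none or still open, it means among the compounds named here.

Compound 1 `CCOC(=O)c1c(-c2ccccc2)[nH]c2cc(OC)ccc2c1=O`, compound 2 `CCOC(=O)c1c(-c2cccc(OCC)c2)[nH]c2cc(OC)ccc2c1=O` and compound 3 `CCOC(=O)c1c(-c2cccc(OC(C)C)c2)[nH]c2cc(OC)ccc2c1=O` share one core and differ only in the group on the phenyl ring. In an ADME assay on HepG2 cells (Homo sapiens) for cytotoxicity, read by luminescence, with a stated time of 72 h (on this read-out lower numbers stand for an effect already at smaller amounts and higher numbers for an effect only at larger amounts of compound), compound 1 gives > 21500 nM, which is a limit of the assay. In this assay compound 2 gives > 21500 nM, likewise a limit. In this assay compound 3 gives > 21500 nM, again a limit. Compound 2 thus stands only at a limit, and the limit of > 21500 nM in this assay, at which 3 of the 3 values shown sit, shows that every value shown sits there. The steps a step that the two limits leave unreadable from compound 1 to compound 2, a step that the two limits leave unreadable from compound 1 to compound 3 and a step that the two limits leave unreadable from compound 2 to compound 3 are accordingly unreadable. Compound 4 `CCOC(=O)c1c(-c2cccc(Cl)c2)[nH]c2cc(OC)ccc2c1=O` carries chloro in place of ethoxy on an aromatic carbon. For the measured compounds named here, no measured step bears readably on this change, so no step beyond the scatter is expected. The estimate for compound 4 is 30000 nM, between 10000 nM and 100000 nM. The step that the limit leaves unreadable from compound 2 to compound 4 is expected to remain within the scatter.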

Compound 4, half-maximal effective concentration: > 21500 nM
Compound 4 gave a limit, no number (the forecaster's own chance of this, stated with the estimate: 85%); the middle value lies beyond the limit too.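

Compound 4 stands at a limit like compound 1, compound 2 and compound 3, so its steps to these three cannot be read: the limit of > 21500 nM in this assay, at which 4 of the 4 values shown sit.

The compounds shown leave open whether any group on the phenyl ring alters the read-out in this assay.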